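The source may hold more compounds than are shown below. What is called first, only, known or untested is meant among the compounds shown, and "the series" means these compounds.

Compound 1 `COc1cc2c(cc1O)O[C@H](c1ccccc1)CC2=O` gives 6700 nM in a functional assay on B16-BL6 cells (Mus musculus) for cytotoxicity, read by MTT assay, with a stated time of 72 h; on this read-out lower numbers stand for stronger inhibition and higher numbers for weaker inhibition. Compound 2 `O=C1c2ccc(O)cc2O[C@H](c2ccccc2)[C@H]1O` returns only a limit in this assay, namely > 100000 nM. Compound 3 `COc1cc2c(cc1O)O[C@H](c1ccccc1)[C@@H](O)C2=O` likewise returns only a limit in this assay, namely > 100000 nM, so compound 3 has no number and sits at the limit of > 100000 nM in this assay, at which 2 of the 3 values shown sit. Hydroxy in place of hydrogen on a saturated ring carbon produced an at least 14-fold higher number from compound 1 to compound 3 (1.17 log units; beyond the scatter); methoxy in place of hydrogen on an aromatic carbon gave a step that the two limits leave unreadable from compound 2 to compound 3. Compound 4 `COc1c(O)cc2c(c1O)C(=O)[C@H](O)[C@@H](c1ccccc1)O2` differs from compound 3 by hydroxy in place of hydrogen on an aromatic carbon. For the measured compounds named here, no measured step covers an added aromatic hydroxy, and compound 3 stands at a limit, so the expected step in this assay is a number no higher from compound 3 to compound 4 (the limit leaves the size open), nothing beyond the scatter. Compound 4 is therefore expected to give about 100000 nM, within 30000 nM to 300000 nM in this assay, most probably again only as a limit.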

Compound 4, half-maximal inhibitory concentration: > 100000 nM
Compound 4: only a limit was reported; the forecaster's own chance of this, stated with the estimate: 75%; the middle value sits exactly at the limit.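

Compound 3 and compound 4 both stand at a limit, so no step can be read between them: the limit of > 100000 nM in this assay, at which 3 of the 4 values shown sit.

Left open is what hydroxy in place of hydrogen on an aromatic carbon does in a compound that gives a number rather than a limit.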